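Removing a ring methyl from compound 1: what to expect

The source may hold more compounds than are shown below. What is called first, only, known or untested is meant among the compounds shown, and "the series" means these compounds.

Among the compounds with values here, compound 1, `Cc1cc(-c2nc3sc(C)cn3c2/C=N/NC(=N)N)c(C)s1`, is one of two compounds measured in a functional assay on cells (Cancer cell lines, Homo sapiens) for inhibition (on this read-out lower numbers stand for stronger inhibition of growth and higher numbers for weaker inhibition of growth), and its number is the higher of the two: in this assay compound 1 gives 3720 nM. Its companion, compound 2, `N=C(N)N/N=C/c1c(-c2cc(Cl)sc2Cl)nc2n1CCS2`, gives 1820 nM in this assay, a gap that lies beyond the usual scatter of repeated runs, so compound 2 shows the stronger growth inhibition of the pair. The two share the amidinohydrazone-bearing core but differ in more than one place, so no single step can be read between them.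

Compound 3, `Cc1cc(-c2nc3sccn3c2/C=N/NC(=N)N)c(C)s1`, differs from compound 1 in exactly one place: hydrogen in place of methyl on an aromatic carbon. Within the data shown here, the loss of a single carbon from the fused ring system is a small change, and nothing among the measured compounds speaks to it directly. On that basis the step from compound 1 to compound 3 is expected to be modest, and the estimate for it, a 1.1-fold higher number from compound 1 to compound 3 (0.05 log units; within the scatter), sits within the scatter rather than signalling a true change in either direction. Compound 3 is accordingly expected to give about 4200 nM in this assay, with a plausible range from 1500 nM to 11000 nM.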

Compound 3, concentration for 50% growth inhibition: 15500 nM
Estimate against measurement, compound 3: 3.7-fold (0.57 log units) below; the measured number lies above the stated range.
By their numbers in this assay, from the lowest: compound 2; then compound 1; then compound 3.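

In this assay, replacing the methyl with hydrogen on this aromatic carbon, next to the ring sulfur and two ring bonds from the ring nitrogen, gives a 4.2-fold higher number from compound 1 to compound 3 (0.62 log units; beyond the scatter), a step that lies beyond the scatter and runs toward weaker inhibition of growth. Within the data shown here, this is the first single-place comparison, and it shows that the position is not indifferent to substitution: the change removes only one carbon, with no ring, no hydrogen-bond donor or acceptor and no net charge involved, yet the read-out clearly moves. Nothing available accounts for why this one methyl matters to this extent.

The compounds shown rest on one pair and one substituent, so it remains open whether an ethyl group, a chlorine atom or a methoxy group on the same carbon would match the methyl, improve on it or fall back towards hydrogen. On these data alone, it also remains open whether a step of this size would recur for the methyl groups elsewhere on compound 1, or on a core carrying different groups.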